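This account rests on a few compounds, and the source may have more. Where it says the series, first, only, none or still open, it means among the compounds named here.

Measured compounds:
compound 1 `CCCCCCCNc1cnc(C(=O)NCc2ccccc2)cn1` — > 100000 nM
compound 2 `O=C(NCc1ccccc1)c1cncc(Cl)n1` — "not determined" (no result reported)
compound 3 `CCCCNc1nccnc1C(=O)NCc1ccccc1` — > 100000 nM

In an ADME assay on HeLa cells (Homo sapiens) for cytotoxicity, read by microscopy, with a stated time of 6 days (a higher number here means that more compound is tolerated, a lower number that less compound is tolerated), compound 1 gives only a limit of the assay, > 100000 nM, and no number. Compound 3 likewise reaches only a limit in this assay, > 100000 nM. For compound 2 no result is reported in this assay. Compound 1 therefore stands at the edge of what the measurement can show, a position shared with compound 3 because of the limit of > 100000 nM in this assay, at which 2 of the 3 values shown sit.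

Compound 4 `CCCCNc1cnc(C(=O)NCc2ccccc2)cn1` has not yet been measured. It differs from compound 1 by hydrogen in place of propyl on a saturated chain carbon, four bonds along the chain from a nitrogen on an aromatic ring. The shared core and the benzylamide remain untouched; only the saturated chain on the ring nitrogen is shortened.

Since both limits sit at the same point, the step from compound 1 to compound 4 in this assay is expected to be none beyond the scatter, and compound 4 is expected to come out again as a limit rather than as a number. The expected step is a number no higher from compound 1 to compound 4 (the limit leaves the size open). Compound 4 is estimated at 100000 nM, with a range from 50000 nM to 200000 nM.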

Compound 4, minimum cytotoxic concentration: > 100000 nM
Compound 4: only a limit was reported; the forecaster's own chance of this, stated with the estimate: 85%; the middle value lies on the limit itself.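

Among these compounds, compound 4, like compound 1, ends at a limit of the assay rather than at a number, so no step between compound 1 and compound 4 can be read. In this assay the compounds shown leave open at what concentration, if any, cytotoxicity would appear.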